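The compounds below may be only part of what the source reports. "The series", "measured", "known", "first", "only" and "open" are said of these compounds alone.

Of the compounds shown here, two have been tested so far in a functional assay on Bel-7402 cells (Homo sapiens) for antiproliferative activity, read by MTT assay, with a stated time of 72 h; a lower number here means a stronger inhibitor, a higher number a weaker inhibitor. In this assay compound 1 (`COc1cccc(CNCc2c(C(=O)O)n(Cc3ccc(N)cc3)c3cc(C(C)C)ccc23)c1`) gives 9570 nM. Compound 2 (`COc1ccc(Cn2c(C(=O)O)c(CNCc3cc(OC)ccc3O)c3ccc(C)cc32)cc1`) gives > 50000 nM, which is a limit of the assay and not a number, and it stands at the limit of > 50000 nM in this assay, at which 1 of the 2 values shown sits.

Compound 3 (`COc1ccc(Cn2c(C(=O)O)c(CNCc3cccc(O)c3)c3ccc(C)cc32)cc1`) has not yet been measured. It differs from compound 2 in one place: 3-hydroxyphenyl in place of 2-hydroxy-5-methoxyphenyl on a saturated chain carbon bound to an amine nitrogen. The 3-hydroxyphenyl takes the place of the 2-hydroxy-5-methoxyphenyl on a saturated chain carbon bound to an amine nitrogen, and the rest of the structure is unchanged. Among the compounds with values here, no measured pair shows what this change does, so any expectation rests on little. Within the data shown here, the only true number in this assay comes from compound 1, at 9570 nM, and compound 3 is not expected to reach it. The expected step of an at least 1.2-fold lower number from compound 2 to compound 3 (0.09 log units; that floor lies within the scatter) is small, leaning if at all towards a stronger inhibitor, and compound 3 may well also end at the limit. For compound 3 the estimated value is 40000 nM, with an expected range from 15000 nM to 90000 nM.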

Compound 3, half-maximal inhibitory concentration: 19800 nM
For compound 3 the middle estimate is 2.0-fold (0.31 log units) above the measured one; low and high end bracket the measured number.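

In this assay, within the data shown here, the change from 2-hydroxy-5-methoxyphenyl to 3-hydroxyphenyl, on a saturated chain carbon bound to an amine nitrogen, gives an at least 2.5-fold lower number from compound 2 to compound 3 (0.40 log units; beyond the scatter), so the number in this assay does respond to the aryl group at this position, which no earlier pair could show. Compound 2 stands at a limit of the assay and not at a number: the limit of > 50000 nM in this assay, at which 1 of the 3 values shown sits. The step is therefore a floor and its true size may be larger. Compound 3, at 19800 nM, gives this substitution pattern its first true number on the shared core.

The group that leaves differs from the group that enters both in the methoxy group and in the numbering of the hydroxy group, so these compounds cannot say which of the two carries the step. They also leave open how the number would move with a plain phenyl or a 3-aminophenyl at this place, or with a primary amide in place of the carboxylic acid.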